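A few compounds are considered here, and "the series" means these few. Any claim that something is new, unique, unknown or untested is made for them only; others in the source may bear on it.

Measured in an in vivo ADME assay on the whole organism (Rattus norvegicus) for pharmacokinetics; on this read-out higher numbers stand for higher oral bioavailability and lower numbers for lower oral bioavailability:
- compound 1 `COCC1=C(C(=O)NCCCN2CCC(c3ccccc3C#N)CC2)[C@@H](c2ccc(F)c(F)c2)NC(=O)N1`: < 6%
- compound 2 `CC1=C(C(=O)NCCCN2CCC(c3ccc(F)cc3C#N)CC2)[C@@H](c2ccc(F)c(F)c2)NC(=O)N1`: 0%

For the measured compounds named here, compound 2, at 0%, holds the only true number in this small set. Compound 1 carries a methoxymethyl group, and its < 6% is a limit of the assay, not a number.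

Compound 3 `COCC1=C(C(=O)NCCCN2CCC(c3ccc(F)cc3C#N)CC2)[C@@H](c2ccc(F)c(F)c2)NC(=O)N1` differs from compound 2 in one place, where methoxy takes the place of hydrogen on a saturated chain carbon bound to a double-bonded ring carbon: methoxy in place of hydrogen on a saturated chain carbon bound to a double-bonded ring carbon. The same difference can be read as methyl to methoxymethyl. Going by the values given here, no measured pair shows this change alone, so its size in this assay remains a judgement. Only a small rise, within the usual scatter, is expected, and the estimated change is a number 4 percentage points higher from compound 2 to compound 3 (within the scatter). Compound 3 is expected to give 4%, with an estimated range of 0% to 14%.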

Compound 3, oral bioavailability: < 6%
Compound 3 gave a limit, no number; the forecaster's own chance of this, stated with the estimate: 45%; the middle value lies beyond the limit too.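

Compound 3 gives < 6%, which is a limit and not a number, so no step can be read from compound 2 to compound 3 or from compound 1 to compound 3. The compounds shown leave open whether the added methoxy or the added fluoro changes oral bioavailability at all.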